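Ring swap to an acyclic oxime ether at the aryl position

This account rests on a few compounds, and the source may have more. Where it says the series, first, only, none or still open, it means among the compounds named here.

Measured compounds:
- compound 1, `Cc1cc(-c2ccccc2NCC2=NCCN2)on1`: 38.9 nM
- compound 2, `Cc1ccc(-c2ccccc2NCC2=NCCN2)o1`: 2.69 nM
- compound 3, `c1cnc(-c2ccccc2NCC2=NCCN2)nc1`: 10 nM

All three were read in a functional assay for activation of Alpha-1A adrenergic receptor (Homo sapiens), read by calcium flux; a lower number here means that less compound is needed, a higher number that more compound is needed for the effect. Compound 3 sits second highest of the three numbers: compound 2 lies closest, with a 3.7-fold higher number from compound 2 to compound 3 (0.57 log units; beyond the scatter), and compound 1 furthest, with a 3.9-fold lower number from compound 1 to compound 3 (0.59 log units; beyond the scatter). The largest step seen is a 14-fold lower number from compound 1 to compound 2 (1.16 log units; beyond the scatter).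

Compound 4, `CC/C(=N/OC)c1ccccc1NCC1=NCCN1`, is not yet measured. It differs from compound 3 by a group of 6 heavy atoms (4 carbon, 1 nitrogen, 1 oxygen; no ring) in place of a group of 6 heavy atoms (4 carbon, 2 nitrogen; one six-membered aromatic ring with 2 hetero atoms), on an aromatic carbon. Every measured step exchanges one aromatic ring for another at this same carbon, and those swaps moved the number by modest to large amounts in either direction. For the measured compounds named here, none of them trades a ring for an open chain, so no step bears directly on this change; the incoming group shares the count of hydrogen-bond acceptors with the one that leaves. A modest step is therefore expected, direction uncertain, with a slight lean toward a higher number, as a 1.5-fold higher number from compound 3 to compound 4 (0.18 log units; within the scatter). Compound 4 is estimated at 15 nM, within 3 nM to 80 nM.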

Compound 4, half-maximal effective concentration: 87.1 nM
For compound 4 the middle estimate is 5.8-fold (0.76 log units) below the measured one; measured number outside the range, above it.
By their numbers in this assay, from the lowest: compound 2; then compound 3; then compound 1; then compound 4.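

In this assay, for the compounds shown here, the open-chain oxime ether of compound 4 is the first group at this aromatic carbon to give a number above all three ring-bearing compounds (an 8.7-fold higher number from compound 3 to compound 4 (0.94 log units; beyond the scatter); a 32-fold higher number from compound 2 to compound 4 (1.51 log units; beyond the scatter); a 2.2-fold higher number from compound 1 to compound 4 (0.35 log units; beyond the scatter)). Even the smallest of these steps lies beyond the scatter, so a matching count of heavy atoms and hydrogen-bond acceptors did not hold the number near that of the pyrimidin-2-yl group. Nothing available explains this rise.

Going by these compounds, whether the higher number goes with giving up the ring or with this particular chain stays open. An ethyl ester, a primary amide or a plain phenyl ring at the same carbon would help to separate the two.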